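The source may report more compounds than this note shows. Statements on the series, on what has been measured and on what is new or still open speak of the compounds shown alone.

Compound 3, `CCc1ccc2oc(CSc3nnc(CNc4ccccc4)n3CC)nc2c1`, stands at a limit in an assay on isolated protein for inhibition of long-chain fatty acid transport protein 1 (Homo sapiens); a lower number here means a stronger inhibitor, a higher number a weaker inhibitor: in this assay compound 3 gives > 1000 nM, which is a limit and not a measured number. Two other compounds share its core. Compound 1, `CCn1c(CNc2ccccc2)nnc1SCC(=O)Nc1ccc(OC)cc1`, also reaches only a limit, giving > 1000 nM in this assay. Going by the values given here, compound 2, `CCn1c(CNc2ccccc2)nnc1SCC(=O)Nc1ccc(C(=O)OC)cc1`, gives 540 nM in this assay and is the one measured number among the three. Among the compounds with values here, the single measured step, an at least 1.8-fold lower number from compound 1 to compound 2 (0.26 log units; that floor lies within the scatter), sits at the edge of the usual scatter, and the limit of > 1000 nM in this assay, at which 2 of the 3 values shown sit, holds both of the remaining values, so very little is known about how changes on this core move the number.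

Compound 4, `CCn1c(CNc2ccccc2)nnc1SCc1nc2cc(Cl)ccc2o1`, differs from compound 3 in one place: chloro in place of ethyl on an aromatic carbon. Within the data shown here, no measured step touches this part of the shared core; the one step that exists changed a group on a different part of it and so gives no direct guide. With compound 3 at a limit and nothing to suggest a large shift, the expected outcome is no step beyond the scatter, a step that the limit leaves unreadable from compound 3 to compound 4, and compound 4 is most likely to return a limit too. The estimate for compound 4 is 2000 nM, with a range from 700 nM to 8000 nM.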

Compound 4, half-maximal inhibitory concentration: > 1000 nM
Compound 4: only a limit was reported (the forecaster's own chance of this, stated with the estimate: 65%); the middle value does not contradict the limit.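

Compound 3 and compound 4 both stop at a limit in this assay, so the change from ethyl to chloro gives no step that can be read: the limit of > 1000 nM in this assay, at which 3 of the 4 values shown sit.

The compounds shown leave open what actual numbers compound 3 and compound 4 would give, and whether this change moves the number on the shared core at all.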